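Carbonyl substituent swap on the shared core

The source may hold more compounds than are shown below. What is called first, only, known or untested is meant among the compounds shown, and "the series" means these compounds.

Compound 1 `COC(=O)CC(=O)N1N=C(c2ccc(-n3cncn3)cc2)CC1c1ccc(N(C)C)cc1` gives -7.8% in a functional assay on HCC1806 cells (Homo sapiens) for inhibition, read by sulforhodamine B assay, tested at 10 uM; a higher number here means more inhibition at the concentration tested (going by the name of the read-out), a lower number less inhibition. Compound 2 `CN(C)c1ccc(C2CC(c3ccc(-n4cncn4)cc3)=NN2C(=O)c2ccc(F)cc2)cc1` differs from it by 4-fluorophenyl in place of (methoxycarbonyl)methyl on a carbonyl carbon and gives 15.6% in this assay, a step of a number 23.4 percentage points higher from compound 1 to compound 2 (beyond the scatter). Compound 3 `COC(=O)CC(=O)N1N=C(c2ccc(-n3ccnc3)cc2)CC1c1ccc(N(C)C)cc1` carries a different core, the difference being (1H-imidazol-1-yl in place of 1H-1,2,4-triazol-1-yl on an aromatic carbon); in this assay compound 3 gives 2.1%, a step of a number 9.9 percentage points higher from compound 1 to compound 3 (within the scatter). Compound 4 `CN(C)c1ccc(C2CC(c3ccc(-n4ccnc4)cc3)=NN2C(=O)c2ccc(F)cc2)cc1`, not yet measured, differs from compound 3 by 4-fluorophenyl in place of (methoxycarbonyl)methyl on a carbonyl carbon, which is the same change as that from compound 1 to compound 2, made at the same place; it occurs twice among these four compounds. The step from compound 3 to compound 4 is expected to be about a number 22.9 percentage points higher from compound 3 to compound 4 (beyond the scatter), resting on the step of a number 23.4 percentage points higher from compound 1 to compound 2 (beyond the scatter) seen in this assay. Compound 4 is therefore estimated at 25% in this assay, expected between 10% and 40%.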

Compound 4, a percentage reported as inhibition, at one concentration (the size of the read-out at that concentration, not a potency): 7.1%
Estimate against measurement, compound 4: 17.9 percentage points above; the whole stated range lies above it.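

In this assay, 4-fluorophenyl in place of (methoxycarbonyl)methyl on a carbonyl carbon gives a number 5 percentage points higher from compound 3 to compound 4 (within the scatter), so the step does not carry over at its earlier size: the same change on two cores in this assay, a number 23.4 percentage points higher (beyond the scatter) from compound 1 to compound 2 and a number 5 percentage points higher (within the scatter) from compound 3 to compound 4, 18.4 percentage points apart, beyond the scatter of two such steps

Read the other way, 1H-imidazol-1-yl in place of 1H-1,2,4-triazol-1-yl gives a number 8.5 percentage points lower from compound 2 to compound 4 (within the scatter), and this step also depends on its partner group: the same change on two cores in this assay, a number 9.9 percentage points higher (within the scatter) from compound 1 to compound 3 and a number 8.5 percentage points lower (within the scatter) from compound 2 to compound 4, 18.4 percentage points apart, beyond the scatter of two such steps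

The two changes are therefore not additive across these four compounds, but one such set shows neither the reason nor a rule for any further core.

Open, from the compounds shown here alone, is how a carboxylic acid or a longer chain on the carbonyl carbon would behave. Also open, going by these compounds, is whether an amine in place of either ring on the aromatic carbon would follow the same non-additive pattern.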